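Branched versus straight chain at the acyl group

A few compounds are considered here, and "the series" means these few. Any claim that something is new, unique, unknown or untested is made for them only; others in the source may bear on it.

Of the compounds shown here, three sharing the same core have been measured so far. Compound 1 `CCC(=O)/N=C(\N)NCCCc1c[nH]cn1` gives 372 nM in an in vitro assay on Sf9 cells for agonist activity at histamine H2 receptor (Homo sapiens), read by scintillation counting; on this read-out higher numbers stand for an effect only at larger amounts of compound and lower numbers for an effect already at smaller amounts. Compound 2 `CC(=O)/N=C(\N)NCCCc1c[nH]cn1` gives 724 nM in this assay, and compound 3 `CC(C)C(=O)/N=C(\N)NCCCc1c[nH]cn1` gives 110 nM. Compound 3 stands at the lowest number of the three: one step reads a 3.4-fold lower number from compound 1 to compound 3 (0.53 log units; beyond the scatter), and the other reads a 6.6-fold lower number from compound 2 to compound 3 (0.82 log units; beyond the scatter). Between compound 1 and compound 2 the change is a 1.9-fold higher number from compound 1 to compound 2 (0.29 log units; within the scatter).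

Compound 4 `CCCC(=O)/N=C(\N)NCCCc1c[nH]cn1` has not been measured yet. It differs from compound 3 in one place: propyl in place of isopropyl on a carbonyl carbon. The two contain the same atoms, joined differently, so the question is what the branching contributes.

Going by the values given here, no measured step swaps a branched chain for a straight one of equal size. The closest hints are the step from compound 1 to compound 3, where adding a methyl beside the carbonyl gave a lower number, and the step from compound 1 to compound 2, where shortening the straight chain stayed within the scatter. Removing the branch is therefore expected to give back part of that gain, and a modest rise in the number for compound 4 is expected, a 2.7-fold higher number from compound 3 to compound 4 (0.44 log units; beyond the scatter). The estimate for compound 4 is 300 nM, with a range from 120 nM to 750 nM.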

Compound 4, half-maximal effective concentration: 141 nM
Beside the measured number, compound 4's estimate is 2.1-fold (0.33 log units) above it; the measured number falls inside the stated range.
By their numbers in this assay, from the lowest: compounds 3 and 4 (each within the scatter of the next); then compounds 1 and 2 (each within the scatter of the next).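

Swapping isopropyl for propyl on the carbonyl carbon rearranges the same atoms and gives a 1.3-fold higher number from compound 3 to compound 4 (0.11 log units; within the scatter), so in this assay the branch as such makes no readable difference at this position. The new compound also shows that a straight chain can reach the level of the branched one, with a 5.1-fold lower number from compound 2 to compound 4 (0.71 log units; beyond the scatter) and a 2.6-fold lower number from compound 1 to compound 4 (0.42 log units; beyond the scatter); among these four compounds, the larger chains on the carbonyl carbon give the lower numbers, although the step from compound 1 to compound 2 stays within the scatter, so the pattern does not show at every step. Nothing shown here explains why the numbers follow chain size rather than chain shape.

The compounds shown leave open whether the numbers keep falling with a longer chain such as pentyl or hexyl, or whether they turn back up at some length. They also leave open what a more heavily branched tert-butyl group or a ring such as cyclopropyl or phenyl would do on the same carbonyl carbon.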